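Working notes: side-chain swap on compound 1

The compounds below may be only part of what the source reports. "The series", "measured", "known", "first", "only" and "open" are said of these compounds alone.

Measured in an ADME assay on Caco-2 cells (Homo sapiens) for permeability, read by LC-MS, in the apical to basolateral direction, with a stated time of 60 min, at pH 6.5; on this read-out lower numbers stand for lower permeability and higher numbers for higher permeability:
- compound 1 `O=C(NCc1cc(Cl)ccc1-n1cnnn1)[C@@H]1C[C@@H]2C[C@@H]2N1C(=O)[C@H](O)CC1CC1`: 3.6 10^-6 cm/s
- compound 2 `O=C(NCc1cc(Cl)ccc1-n1cnnn1)[C@@H]1CC=NN1C(=O)[C@H](O)c1ccccc1F`: 8.9 10^-6 cm/s

Compound 1 at 3.6 10^-6 cm/s holds the lower of the two numbers, and compound 2 at 8.9 10^-6 cm/s lies beyond the usual scatter from it. These two compounds differ in more than one place, so their gap says nothing about any single change.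

Next in line is compound 3 `O=C(NCc1cc(Cl)ccc1-n1cnnn1)[C@@H]1C[C@@H]2C[C@@H]2N1C(=O)[C@H](O)C1CCCCC1`, which keeps the core of compound 1. It carries cyclohexyl in place of cyclopropylmethyl on a saturated chain carbon bound to a carbonyl carbon and an oxygen on a saturated carbon. Within the data shown here, no measured pair shows this swap, so the data give no direct guide to its size in this assay and compound 1 remains the only anchor.

A small upward move, not beyond the scatter, is expected, and the estimated step is a 1.3-fold higher number from compound 1 to compound 3 (0.10 log units; within the scatter) in this read-out. Compound 3 is estimated at 4.5 10^-6 cm/s within an expected range of 2 10^-6 cm/s to 10 10^-6 cm/s for this measurement.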

Compound 3, apparent permeability: 16 10^-6 cm/s
Compound 3: the middle estimate sits 3.6-fold (0.55 log units) below what was measured; the whole stated range lies below it.
By their numbers in this assay, from the lowest: compound 1; then compounds 2 and 3 (each within the scatter of the next).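

Among these compounds, on the saturated chain carbon bound to a carbonyl carbon and an oxygen on a saturated carbon, the side chain alone is now seen to move the number in this assay: cyclohexyl in place of cyclopropylmethyl gives a 4.4-fold higher number from compound 1 to compound 3 (0.65 log units; beyond the scatter) on the core of compound 1, the first single-place step and one that lies beyond the scatter. Both groups are counted with no hydrogen-bond donors, no hydrogen-bond acceptors and no net charge, so a step of this size at this position arises with none of these counts changing, while the ring size and the number of heavy atoms do change. Nothing at hand speaks to what lies behind the step.

From the compounds shown here alone, a single swap cannot separate ring size from carbon count, so it stays open how a cyclopentyl ring, a phenyl ring or an open chain such as n-hexyl would read on the same carbon. Going by these compounds, it is also open whether a basic amine or a carboxylic acid on this side chain would keep the higher number, and whether the swap would give a similar step on the core of compound 2.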